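Amide substituents on a shared core in a cell assay

The source may hold more compounds than are shown below. What is called first, only, known or untested is meant among the compounds shown, and "the series" means these compounds.

Compound 1 `CCn1c(C(=O)N[C@@H](C)C(=O)OC)ccc1C(CC)(CC)c1ccc(OCS(=O)(=O)c2ccccc2)c(C)c1`: 17900 nM
Compound 2 `CCN(CC)CCNC(=O)c1ccc(C(CC)(CC)c2ccc(OCS(=O)(=O)c3ccccc3)c(C)c2)n1CC`: 6270 nM
Compound 3 `CCn1c(C(=O)N[C@@H](CO)C(C)C)ccc1C(CC)(CC)c1ccc(OCS(=O)(=O)c2ccccc2)c(C)c1`: 13200 nM

All three were tested in a functional assay on BXPC-3 cells (Homo sapiens) for antiproliferative activity, read by MTT assay, with a stated time of 24 h; a higher number here means a weaker inhibitor, a lower number a stronger inhibitor. Compound 2 gives the lowest of the three numbers; the nearest is compound 3, shown by a 2.1-fold higher number from compound 2 to compound 3 (0.32 log units; beyond the scatter), and the furthest is compound 1, shown by a 2.9-fold lower number from compound 1 to compound 2 (0.46 log units; beyond the scatter). The difference between compound 1 and compound 3 is a 1.4-fold lower number from compound 1 to compound 3 (0.13 log units; within the scatter).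

Compound 4 `CCn1c(C(=O)N[C@H](CO)CCCO)ccc1C(CC)(CC)c1ccc(OCS(=O)(=O)c2ccccc2)c(C)c1` has not yet been measured. It differs from compound 2 in one place: a group of 7 heavy atoms (5 carbon, 2 oxygen; no ring) in place of a group of 7 heavy atoms (6 carbon, 1 nitrogen; no ring), on an amide-type nitrogen.

The step that bears most directly on this change is a 2.1-fold higher number from compound 2 to compound 3 (0.32 log units; beyond the scatter), where the 2-(diethylamino)ethyl group was likewise replaced by a hydroxyl-bearing substituent on the amide-type nitrogen, and the number rose by a modest amount. The change to compound 4 again exchanges the 2-(diethylamino)ethyl group for a chain carrying two hydroxyl groups, so a modest rise of similar size is expected rather than a fall. The expected step is a 1.9-fold higher number from compound 2 to compound 4 (0.28 log units; within the scatter). Compound 4 is therefore estimated to give 12000 nM, with a range from 5000 nM to 30000 nM.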

Compound 4, half-maximal inhibitory concentration: > 50000 nM
Compound 4 was reported as a limit (the forecaster's own chance of this, stated with the estimate: 5%); middle value at least 4.1-fold (0.61 log units) from the limit.
By their numbers in this assay, from the lowest: compound 2; then compounds 3 and 1 (each within the scatter of the next). At a limit, above all of these: compound 4.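

Replacing 2-(diethylamino)ethyl on the amide-type nitrogen with the new group gives an at least 7.9-fold higher number from compound 2 to compound 4 (0.90 log units; beyond the scatter) in this assay and goes well past the rise seen for compound 3. Substituents bearing hydroxyl groups are thus not interchangeable at this position, for the new group also gives an at least 3.7-fold higher number from compound 3 to compound 4 (0.57 log units; beyond the scatter) and an at least 2.7-fold higher number from compound 1 to compound 4 (0.44 log units; beyond the scatter) in the same assay. The value of compound 4 is a limit: the limit of > 50000 nM in this assay, at which 1 of the 4 values shown sits.

The compounds shown leave open whether the lower number of compound 2 goes with its diethylamino nitrogen or with the absence of hydroxyl groups, as each step exchanges a whole substituent. They also do not tell how a primary amine, a carboxylic acid or a longer chain ending in diethylamino would read on this nitrogen.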